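The compounds below may be only part of what the source reports. "The series", "measured", "known", "first", "only" and "open" are said of these compounds alone.

Measured so far:
Compound 1 `N#CC1=C(N)Oc2c(c3nc4ccccc4nc3c3ccccc23)C12C(=O)N(Cc1cnnn1-c1cc(Cl)ccc1Cl)c1ccccc12` gives > 50000 nM in a functional assay on A549 cells (Homo sapiens) for antiproliferative activity, read by MTT assay, with a stated time of 48 h (on this read-out higher numbers stand for weaker inhibition and lower numbers for stronger inhibition), which is a limit of the assay rather than a number.
Compound 2 `N#CC1=C(N)Oc2c(c3nc4ccccc4nc3c3ccccc23)C12C(=O)N(Cc1cnnn1-c1ccc(Cl)c(Cl)c1)c1ccccc12` gives > 50000 nM in this assay, again a limit rather than a number.
Compound 3 `COc1ccccc1-n1nncc1CN1C(=O)C2(C(C#N)=C(N)Oc3c(N)cc4nc5ccccc5nc4c32)c2ccccc21` gives 37500 nM in this assay.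

Compound 3 thus stands as the only one of the three with a numerical value; the other two sit at the limit described in the limit of > 50000 nM in this assay, at which 2 of the 3 values shown sit. The compound to be measured is compound 4 `N#CC1=C(N)Oc2c(N)cc3nc4ccccc4nc3c2C12C(=O)N(Cc1cnnn1-c1ccc(Cl)cc1[N+](=O)[O-])c1ccccc12`. It differs from compound 3 in one place: 4-chloro-2-nitrophenyl in place of 2-methoxyphenyl on an aromatic nitrogen.

Among the measured compounds shown here, only one measured step exists between compounds that differ in a single place, a step that the two limits leave unreadable from compound 1 to compound 2. It concerns the same part of the molecule, the aromatic ring on the triazole nitrogen, but its size cannot be read, since both ends are limits. For the measured compounds named here, there is therefore no measured step that tells how large a change at this position can be, and no basis for expecting a step beyond the usual scatter in this assay in either direction.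

The estimate for compound 4 is therefore close to compound 3, with the step of a 1.1-fold higher number from compound 3 to compound 4 (0.03 log units; within the scatter) expected to stay within the scatter, giving an expected value of 40000 nM with a range from 15000 nM to 100000 nM.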

Compound 4, half-maximal inhibitory concentration: > 50000 nM
Compound 4 gave a limit, no number; the forecaster's own chance of this, stated with the estimate: 45%; middle value at least 1.2-fold (0.09 log units) from the limit.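

This position now has its first step with a readable floor, for 4-chloro-2-nitrophenyl in place of 2-methoxyphenyl: an at least 1.3-fold higher number from compound 3 to compound 4 (0.12 log units; that floor lies within the scatter). In this assay compound 4 gives > 50000 nM, which is a limit of the assay and not a number. The floor alone does not show a real loss, but the change brings no clear gain in inhibition, and the series stays mostly at the same ceiling: the limit of > 50000 nM in this assay, at which 3 of the 4 values shown sit.

On these data alone, how far the true value of compound 4 lies beyond its limit remains unknown, so the full size of the step could be small or large. Also open, as far as these compounds go, is whether a plain phenyl, or a phenyl carrying an amine or a carboxylic acid in place of the methoxy group, would give a clearly lower number than compound 3 at 37500 nM, and thus show whether this position can move inhibition at all.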